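The source may hold more compounds than are shown below. What is called first, only, known or untested is meant among the compounds shown, and "the series" means these compounds.

Measured so far in a functional assay on NUGC-3 cells (Homo sapiens) for antiproliferative activity, read by sulforhodamine B assay; a lower number here means a stronger inhibitor of growth, a higher number a weaker inhibitor of growth:
compound 1 `COc1ccc(C(=O)Nc2nc3cc(OC)ccc3s2)cc1`: > 10 ug/mL, a limit only
compound 2 `COc1ccc2nc(NC(=O)c3ccc(C)cc3)sc2c1`: > 10 ug/mL, a limit only
compound 3 `Cc1ccc(C(=O)Nc2nc3cc(C)cc(C)c3s2)cc1`: 2.37 ug/mL

Compound 1 stands at the limit of > 10 ug/mL in this assay, at which 2 of the 3 values shown sit, so for compound 1 only a limit is known in this assay. Compound 2 sits at the same limit. Compound 3 alone gives a number. Compound 4 `COc1ccc2sc(NC(=O)c3ccc(C(F)(F)F)cc3)nc2c1` differs from compound 1 by trifluoromethyl in place of methoxy on an aromatic carbon. Going by the values given here, no measured pair shows what this change does. With compound 1 resting on a limit, the step to compound 4 cannot be sized from measurement; in this assay a small step is expected, if anything toward stronger growth inhibition, with a real chance that compound 4 also stops at the limit. For compound 4 the estimate is 7 ug/mL, between 2.5 ug/mL and 20 ug/mL. This expected value means a step of an at least 1.4-fold lower number from compound 1 to compound 4 (0.15 log units; that floor lies within the scatter).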

Compound 4, concentration for 50% growth inhibition: > 10 ug/mL
Compound 4 gave a limit, no number; the forecaster's own chance of this, stated with the estimate: 55%; middle value at least 1.4-fold (0.15 log units) from the limit.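

In this assay, going by these compounds alone, compound 4 gives > 10 ug/mL, a limit and not a number, and compound 1 also rests on a limit, so no step between compound 1 and compound 4 can be read: the limit of > 10 ug/mL in this assay, at which 3 of the 4 values shown sit.

On these data alone, whether trifluoromethyl in place of methoxy on an aromatic carbon changes growth inhibition in this assay remains open.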